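Trimming a Phenyl to Methyl on an Inactive Core

The source may report more compounds than this note shows. Statements on the series, on what has been measured and on what is new or still open speak of the compounds shown alone.

Compound 1 `CN(C)c1ccc(/C=C2/SC(N(c3ccccc3)c3ccccc3)=NC2=O)cc1` was tested in a functional assay on H460/TaxR cells (Homo sapiens) for cytotoxicity, read by sulforhodamine B assay, with a stated time of 48 h; a lower number here means that less compound is needed, a higher number that more compound is needed for the effect. In this assay compound 1 reaches only the limit of > 100000 nM, so no number is known for it. Compound 2 `CCN(CC)c1ccc(/C=C2/SC(N(c3ccccc3)c3ccccc3)=NC2=O)cc1` likewise sits at the limit of > 100000 nM in this assay. Compound 3 `CN1CCN(c2ccc(/C=C3/SC(N(c4ccccc4)c4ccccc4)=NC3=O)cc2)CC1` also gives only the limit of > 100000 nM. The steps a step that the two limits leave unreadable from compound 1 to compound 2, a step that the two limits leave unreadable from compound 1 to compound 3 and a step that the two limits leave unreadable from compound 2 to compound 3 are all unreadable, as the limit of > 100000 nM in this assay, at which 3 of the 3 values shown sit, shows. Compound 4 `CN(C)c1ccc(/C=C2/SC(N(C)c3ccccc3)=NC2=O)cc1` differs from compound 1 at a different place: methyl in place of phenyl on a nitrogen on an aromatic ring. For the measured compounds named here, no measured step touches this position, so the three unreadable steps give no guide to its size or direction. The expected step is a number no higher from compound 1 to compound 4 (the limit leaves the size open), a guess resting on nothing measured. Compound 4 is estimated at 100000 nM, within a range from 10000 nM to 300000 nM.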

Compound 4, half-maximal effective concentration: 160 nM
The estimate for compound 4 lay 630-fold (2.80 log units) above the measured number, outside the stated range (below it).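

This position on the nitrogen is where the activity appears: in this assay, methyl in place of phenyl gives an at least 620-fold lower number from compound 1 to compound 4 (2.79 log units; beyond the scatter). For the compounds shown here, the three earlier steps between amino groups cannot be read, so only this change shows that the shared core can be active at all. Going by these compounds, the step is only a minimum, and its true size stays open because compound 1 rests on a limit: the limit of > 100000 nM in this assay, at which 3 of the 4 values shown sit.

On these data alone, whether an ethyl group or a longer chain on this nitrogen would keep the effect remains open. So does whether diethylamino or 4-methylpiperazin-1-yl would change the number with methyl in place.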